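Replacing a Pyrrolidinylethyl Arm with a Benzimidazole

The compounds below may be only part of what the source reports. "The series", "measured", "known", "first", "only" and "open" are said of these compounds alone.

Of the compounds shown here, three share one core and have been measured in a physicochemical assay for lipophilicity; a higher number here means a more lipophilic compound, a lower number a more polar compound. Compound 3 `CC(C)Sc1nnc(-c2c(CNCCN3CCCC3)c3ccccc3n2C)n1-c1ccccc1` gives 4.83 in this assay. Compound 1 `CC(C)Sc1nnc(-c2c(CNCCN3CCCC3)c3cc(F)ccc3n2C)n1-c1ccccc1` gives 4.99, and compound 2 `CC(C)Sc1nnc(-c2c(CN3CCC(N4CCCC4)CC3)c3ccccc3n2C)n1-c1ccccc1` gives 5.16. Among these three numbers compound 3 stands lowest, though its gap to compound 1 lies within the scatter; only compound 2 sits clearly apart from it.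

Two single-point steps have been measured: a number 0.16 log units lower from compound 1 to compound 3 (within the scatter), and a number 0.33 log units lower from compound 2 to compound 3 (beyond the scatter). The second of these touches the same amine arm that changes in the next compound, and it shows that exchanging the group on that arm can move this assay by a modest but real amount.

Compound 4 `CC(C)Sc1nnc(-c2c(CNc3nc4ccccc4[nH]3)c3ccccc3n2C)n1-c1ccccc1` has not yet been measured. It differs from compound 3 in that (1H-benzimidazol-2-yl in place of 2-(pyrrolidin-1-yl)ethyl on an amine nitrogen). Neither measured step exchanges a saturated amine-bearing chain for a fused aromatic group, so they set only a scale, not a direction. On the shown data, compound 4 is expected to come out more lipophilic, with an estimated step of a number 1.07 log units higher from compound 3 to compound 4 (beyond the scatter). The estimated value for compound 4 is 5.9, expected to fall between 5.2 and 6.6.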

Compound 4, partition coefficient: 5.94
The estimate for compound 4 lay 0.04 log units below the measured number; the measured number falls inside the stated range.
By their numbers in this assay, from the lowest: compounds 3, 1 and 2 (each within the scatter of the next, the first and the last beyond it); then compound 4.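

In this assay, among the compounds shown here, the amine nitrogen of the shared core proves able to carry a much larger shift than the earlier compounds suggested: putting 1H-benzimidazol-2-yl in place of 2-(pyrrolidin-1-yl)ethyl gives a step (a number 1.11 log units higher from compound 3 to compound 4 (beyond the scatter)) well beyond the one between the two saturated arms (a number 0.33 log units lower from compound 2 to compound 3 (beyond the scatter)). The new arm also clears the highest of the earlier numbers (a number 0.78 log units higher from compound 2 to compound 4 (beyond the scatter)), so both arms that carry a pyrrolidine ring, in compound 2 and compound 3, now stand below the arm with the fused aromatic rings in compound 4. Nothing shown accounts for why the number rises this far.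

This single exchange removes a saturated ring and a chain while adding two aromatic rings and a hydrogen-bond donor, so the compounds shown cannot tell which of these parts carries the rise. A smaller aromatic arm on the same nitrogen, such as phenyl or 1H-imidazol-2-yl, would help to separate them, and a fluoro group on the core of compound 4 remains an open combination.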